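Three Limits and a New Aryl Group

This account rests on a few compounds, and the source may have more. Where it says the series, first, only, none or still open, it means among the compounds named here.

Compound 3 `CCOC(=O)CCCCCOc1cccc(CN(C(=O)c2ccc(-c3cc(OC)cc(OC)c3)cc2)C(C)C)c1` was tested in an ADME assay on Raji cells (Homo sapiens) for cytotoxicity, read by CellTiter-Glo and resazurin assay, with a stated time of 72 h; a lower number here means that less compound is needed, a higher number that more compound is needed for the effect. In this assay compound 3 reaches only a limit, > 26000 nM. Compound 1 `CCOC(=O)CCCCCOc1cccc(CN(C(=O)c2ccc(-c3cccc(-c4ccccc4)c3)cc2)C(C)C)c1` likewise gives only a limit, > 26000 nM. Compound 2 `CCOC(=O)CCCCCOc1cccc(CN(C(=O)c2ccc(-c3ccc4c(c3)OCCO4)cc2)C(C)C)c1` also gives only a limit, > 24400 nM. Compound 4 `CCOC(=O)CCCCCOc1cccc(CN(C(=O)c2ccc(-c3cccc(OC(F)(F)F)c3)cc2)C(C)C)c1` differs from compound 3 by 3-(trifluoromethoxy)phenyl in place of 3,5-dimethoxyphenyl on an aromatic carbon. The measured steps that bear on this change are a step that the two limits leave unreadable from compound 1 to compound 3, a step that the two limits leave unreadable from compound 2 to compound 3 and a step that the two limits leave unreadable from compound 1 to compound 2; each joins two limits, so no size can be read from any of them. With every value at a limit, nothing points to a change beyond the scatter, and compound 4 is expected to end at a limit as well. The estimate for compound 4 is 30000 nM, between 10000 nM and 100000 nM. The step from compound 3 to compound 4 is therefore expected to be a step that the limit leaves unreadable from compound 3 to compound 4.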

Compound 4, half-maximal effective concentration: > 26000 nM
Compound 4: no number, only a limit (the forecaster's own chance of this, stated with the estimate: 90%); the middle value lies beyond the limit too.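

Compound 4 ends at a limit, as compounds 1, 2 and 3 do, so none of the steps joining it to them can be read. The compounds shown leave open at what concentration any of them takes effect, and whether changing the aryl group alters that.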